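A New Ring on the Carbonyl of Compound 1

The compounds below may be only part of what the source reports. "The series", "measured", "known", "first", "only" and "open" are said of these compounds alone.

In an ADME assay on MT4 cells (Homo sapiens) for cytotoxicity, read by MTT assay (on this read-out higher numbers stand for lower toxicity in this test and lower numbers for higher toxicity in this test), compound 1 `Cc1ccc(C(=O)N(C(=S)OCCN2C(=O)c3ccccc3C2=O)c2ccc(Cl)cc2)cc1` gives > 100000 nM, which is a limit and not a number. That makes it (the limit of > 100000 nM in this assay, at which 1 of the 3 values shown sits). Compound 2 `Cc1ccc(C(=O)N(C(=S)OCCN2C(=O)c3ccccc3C2=O)c2ccc(C)cc2)cc1` gives 83000 nM, and the step is an at least 1.2-fold lower number from compound 1 to compound 2 (0.08 log units; that floor lies within the scatter), with methyl in place of chloro on an aromatic carbon. That step leaves the 4-methylphenyl on the carbonyl carbon untouched. Differing from compound 1 in more than one place, including the group on the carbonyl carbon, compound 3 `O=C1c2ccccc2C(=O)N1CCOC(=S)N(C(=O)c1ccc(Cl)c(Cl)c1)c1ccccc1` gives 52000 nM. Compound 4 `O=C1c2ccccc2C(=O)N1CCOC(=S)N(C(=O)c1c(F)cccc1F)c1ccc(Cl)cc1` brings (2,6-difluorophenyl in place of 4-methylphenyl on a carbonyl carbon), which is 2,6-difluorophenyl in place of 4-methylphenyl on a carbonyl carbon. Among the compounds with values here, no measured step isolates this change, so only a small move to a lower number is expected. The expected step is an at least 1.4-fold lower number from compound 1 to compound 4 (0.15 log units; that floor lies within the scatter). For compound 4 the estimated value is 70000 nM, with an expected range from 30000 nM to 100000 nM.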

Compound 4, half-maximal cytotoxic concentration: 39000 nM
Compound 4: the middle estimate sits 1.8-fold (0.25 log units) above what was measured, and the stated range covers the measured number.
By their numbers in this assay, from the lowest: compounds 4, 3 and 2 (each within the scatter of the next, the first and the last beyond it). At a limit, above all of these: compound 1.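

At the carbonyl carbon, 2,6-difluorophenyl in place of 4-methylphenyl gives an at least 2.5-fold lower number from compound 1 to compound 4 (0.40 log units; beyond the scatter), so a change at this position can shift the number in this assay beyond the scatter, toward higher toxicity in this test. Within the data shown here, the only earlier step, made on an aromatic carbon, has a floor within the scatter. Compound 1 stands at a limit and not at a number, so this step could be larger: the limit of > 100000 nM in this assay, at which 1 of the 4 values shown sits.

On these data alone, whether the two fluorines or the lost methyl matter more remains open. So does what a plain phenyl or a cyclohexyl on this carbonyl carbon would give.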